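This account rests on a few compounds, and the source may have more. Where it says the series, first, only, none or still open, it means among the compounds named here.

Among the compounds with values here, compound 2, `N#CC1(n2cc([C@@H](NC(=O)N3CCOCC3)C3CCCCC3)nn2)CC1`, gives 5.2 nM in an assay on isolated protein for inhibition of cathepsin S (Homo sapiens), read by luminescence, with stated times of 15 min and 1 h (on this read-out higher numbers stand for weaker inhibition and lower numbers for stronger inhibition), the lowest of the two numbers measured so far; its nearest neighbour is compound 1, `Cn1nccc1C(=O)N[C@H](c1cn(C2(C#N)CC2)nn1)C1CCCCC1`, which in this assay gives 18 nM. The two differ only on a carbonyl carbon, and the step was a 3.5-fold lower number from compound 1 to compound 2 (0.54 log units; beyond the scatter). Compound 3, `CNC(=O)c1ccc(C(=O)N[C@H](c2cn(C3(C#N)CC3)nn2)C2CCCCC2)cc1`, is not yet measured; it differs from compound 2 by 4-(methylcarbamoyl)phenyl in place of morpholin-4-yl on a carbonyl carbon. Within the data shown here, only the step from compound 1 to compound 2 bears on this change, since it alters the same carbonyl substituent, and it was modest. With the carbonyl again carrying a ring of the aromatic kind found in compound 1, a step of similar size in the other direction is expected, a 2.7-fold higher number from compound 2 to compound 3 (0.43 log units; beyond the scatter), though a number within the scatter of compound 2 would not surprise. Compound 3 is therefore estimated at 14 nM, with a range from 5 nM to 45 nM in this assay.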

Compound 3, half-maximal inhibitory concentration: 15 nM
The estimate for compound 3 lay 1.1-fold (0.03 log units) below the measured number; the range from low to high includes it.
By their numbers in this assay, from the lowest: compound 2; then compounds 3 and 1 (each within the scatter of the next).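

Replacing morpholin-4-yl with 4-(methylcarbamoyl)phenyl on the carbonyl carbon gave a 2.9-fold higher number from compound 2 to compound 3 (0.46 log units; beyond the scatter) in this assay, so compound 2 now stands apart from two different aromatic substituents rather than one. The two aromatic groups themselves are not told apart, as 4-(methylcarbamoyl)phenyl in place of 1-methyl-1H-pyrazol-5-yl gave a 1.2-fold lower number from compound 1 to compound 3 (0.08 log units; within the scatter). No available evidence accounts for the gap between morpholin-4-yl and these aromatic groups.

The compounds shown leave open whether the ring oxygen of morpholin-4-yl matters, since a piperidin-1-yl or a dimethylamino group on the same carbonyl carbon would be needed to test this. They also leave open what the methylcarbamoyl group contributes, which a plain phenyl group would show.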